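Pyridin-4-yl replaces 4-methoxyphenyl on the piperazine nitrogen

A few compounds are considered here, and "the series" means these few. Any claim that something is new, unique, unknown or untested is made for them only; others in the source may bear on it.

Measured so far in a functional assay on MGC-803 cells (Homo sapiens) for antiproliferative activity, read by CCK-8 assay, with a stated time of 72 h, tested at 8 uM; on this read-out higher numbers stand for a stronger effect at the one concentration tested and lower numbers for a weaker effect:
- compound 1 `Nc1ccccc1NC(=O)c1ccc(CSC(=S)N2CCN(c3ccc(Cl)cc3)CC2)cc1` gives 17.2%
- compound 2 `Nc1ccccc1NC(=O)c1ccc(CSC(=S)N2CCN(C3CCCCC3)CC2)cc1` gives 75.3%
- compound 3 `COc1ccc(N2CCN(C(=S)SCc3ccc(C(=O)Nc4ccccc4N)cc3)CC2)cc1` gives 22.9%

Compound 3 stands second highest of the three numbers. Its nearest neighbour is compound 1, a step of a number 5.7 percentage points higher from compound 1 to compound 3 (within the scatter) that stays within the scatter. Its furthest is compound 2, since a number 52.4 percentage points lower from compound 2 to compound 3 (beyond the scatter) is a large fall. Compound 4 `Nc1ccccc1NC(=O)c1ccc(CSC(=S)N2CCN(c3ccncc3)CC2)cc1`, not yet measured, differs from compound 3 in one place: pyridin-4-yl in place of 4-methoxyphenyl on an amine nitrogen in a ring.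

Within the data shown here, no measured step swaps one aromatic group for another on that ring nitrogen except the step from compound 1 to compound 3, which was within the scatter. The two large steps both involve cyclohexyl entering or leaving. One of them is a number 58.1 percentage points higher from compound 1 to compound 2 (beyond the scatter). The other is the fall from compound 2 to compound 3. Compound 4 keeps a six-membered aromatic ring there. The step for compound 4 is therefore expected to be small, about a number 2.1 percentage points higher from compound 3 to compound 4 (within the scatter), with no clear direction. Compound 4 is estimated at 25% in this assay, within a range from 8% to 50%.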

Compound 4, a percentage reported as inhibition, at one concentration (the size of the read-out at that concentration, not a potency): 87.1%
Compound 4: the middle estimate sits 62.1 percentage points below what was measured; measured number outside the range, above it.
By their numbers in this assay, from the lowest: compounds 1 and 3 (each within the scatter of the next); then compound 2; then compound 4.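

In this assay, pyridin-4-yl on the amine nitrogen in a ring brings a number 64.2 percentage points higher from compound 3 to compound 4 (beyond the scatter) and a number 69.9 percentage points higher from compound 1 to compound 4 (beyond the scatter), so a six-membered aromatic ring at this place does not in itself go with a low number, and the swap of one aromatic group for another can matter greatly here. Cyclohexyl is also not needed for a high number: the change to pyridin-4-yl gives a number 11.8 percentage points higher from compound 2 to compound 4 (beyond the scatter), which makes compound 4 the strongest of the four at this single concentration. Nothing available explains why this aromatic ring behaves so differently from the other two.

With a single ring of this kind shown, it remains open how pyridin-3-yl, pyridin-2-yl or plain phenyl would read at this place. Going by these compounds, whether the order of the four compounds would hold at other concentrations or in other cell lines also remains open.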